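A Methyl Added Near an Alkene on a Weak Analog

The source may report more compounds than this note shows. Statements on the series, on what has been measured and on what is new or still open speak of the compounds shown alone.

Compound 1 `CC/C=C\C(=O)Nc1cc(Nc2ncc(C#N)c(-c3cn(C)c4ccccc34)n2)c(OC)cc1N(C)CCN(C)C` and compound 2 `CCC/C=C\C(=O)Nc1cc(Nc2ncc(C#N)c(-c3cn(C)c4ccccc34)n2)c(OC)cc1N(C)CCN(C)C` share one core, and in a functional assay on A549 cells (Homo sapiens) for antiproliferative activity, read by MTT assay, with a stated time of 72 h (a lower number here means a stronger inhibitor, a higher number a weaker inhibitor), compound 1 gives 162 nM while compound 2 gives 166 nM. The change between them, (methyl in place of hydrogen on a saturated chain carbon, two bonds along the chain from a double-bonded chain carbon), makes a 1.0-fold higher number from compound 1 to compound 2 (0.01 log units; within the scatter). Compound 3 `CC/C=C\C(=O)Nc1cc(Nc2nccc(-c3cn(C)c4ccc(F)cc34)n2)c(OC)cc1N(C)CCN(C)C` rests on a different core; the difference between the two cores is not broken down here. In this assay compound 3 gives 3600 nM, the highest of the three numbers and beyond the scatter from both others. Compound 4 `COc1cc(N(C)CCN(C)C)c(NC(=O)/C=C\C(C)C)cc1Nc1nccc(-c2cn(C)c3ccc(F)cc23)n1` is not yet measured; it differs from compound 3 by methyl in place of hydrogen on a saturated chain carbon bound to a double-bonded chain carbon and a saturated chain carbon. This is the same kind of change as from compound 1 to compound 2, but the place differs: there the methyl enters two bonds along the chain from a double-bonded chain carbon, here on a carbon bound to a double-bonded chain carbon and a saturated chain carbon. For compound 4 the expected step is no change at the digits printed from compound 3 to compound 4 (within the scatter), because the earlier one was a 1.0-fold higher number from compound 1 to compound 2 (0.01 log units; within the scatter). Compound 4 is estimated at 3600 nM, with a likely range from 1500 nM to 8500 nM.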

Compound 4, half-maximal inhibitory concentration: 6140 nM
Estimate against measurement, compound 4: 1.7-fold (0.23 log units) below; the range from low to high includes it.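

In this assay, placing a methyl on the chain of the weak analog gives a 1.7-fold higher number from compound 3 to compound 4 (0.23 log units; within the scatter), so the number stays within the scatter on this core as well. Set side by side, the two steps do not differ measurably: the same change on two cores in this assay, a 1.0-fold higher number (0.01 log units; within the scatter) from compound 1 to compound 2 and a 1.7-fold higher number (0.23 log units; within the scatter) from compound 3 to compound 4, 1.7-fold (0.22 log units) apart, within the scatter of two such steps This suggests that, for these two pairs, the methyl carries from one core to the other without a clear effect, but it gives no general rule for other cores, and since the methyl sits at a different place on the chain in each pair, the effects of place and core remain unseparated.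

As far as these compounds go, it remains open whether a larger group on this chain, such as a longer chain, a phenyl ring or an amine, would change the number. Also open, from the compounds shown here alone, is how each methyl placement would read on the other core.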